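Benzyloxy Homologue of Compound 1 in a Cytotoxicity Assay

The source may report more compounds than this note shows. Statements on the series, on what has been measured and on what is new or still open speak of the compounds shown alone.

Compound 1 `COc1ccc(C(O)C2OC(=O)c3c(OC)cc(OC)cc32)cc1`: > 40000 nM
Compound 2 `COCCCOc1ccc(C(O)C2OC(=O)c3c(OC)cc(OC)cc32)cc1`: > 40000 nM
Compound 3 `CCOCCOc1ccc(C(O)C2OC(=O)c3c(OC)cc(OC)cc32)cc1`: > 40000 nM

Each of these values in an ADME assay on RAW264.7 cells (Mus musculus) for cytotoxicity, read by MTT assay, with a stated time of 24 h, in the absence of a further agent (a lower number here means a stronger inhibitor, a higher number a weaker inhibitor), is a limit of the assay and not a number. All three sit at the limit of > 40000 nM in this assay, at which 3 of the 3 values shown sit, so compound 1 stands only as a limit here and cannot be set in order against compound 2 or compound 3. Compound 4, `COc1cc(OC)c2c(c1)C(C(O)c1ccc(OCc3ccccc3)cc1)OC2=O`, differs from compound 1 by phenyl in place of hydrogen on a saturated chain carbon bound to an oxygen on an aromatic ring. The measured steps that bear on this change are a step that the two limits leave unreadable from compound 1 to compound 2 and a step that the two limits leave unreadable from compound 1 to compound 3; both are unreadable, so they give neither a size nor a direction. Compound 4 is therefore expected to remain at the same limit, with an estimate of 40000 nM and a range from 20000 nM to 80000 nM, which means an expected step of a number no higher from compound 1 to compound 4 (the limit leaves the size open), not beyond the scatter.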

Compound 4, half-maximal inhibitory concentration: > 40000 nM
Compound 4 ended at the assay's limit; the forecaster's own chance of this, stated with the estimate: 85%; the middle value lies on the limit itself.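

In this assay compound 4 gives > 40000 nM, a limit and not a number, so its steps to compound 1, compound 2 and compound 3 cannot be read. The compounds shown leave open whether benzyloxy in place of methoxy changes cytotoxicity at all.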